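A Halogen Swap on Compound 1: What to Expect

A few compounds are considered here, and "the series" means these few. Any claim that something is new, unique, unknown or untested is made for them only; others in the source may bear on it.

Measured compounds:
compound 1 `CCCCS(=O)(=O)Oc1ccc(/C=C/C(=O)Nc2ccccc2)cc1OC` — 3320 nM
compound 2 `CCCCS(=O)(=O)Oc1ccc(/C=C/C(=O)Nc2ccccc2Br)cc1OC` — 5000 nM
compound 3 `CCCCS(=O)(=O)Oc1ccc(/C=C/C(=O)Nc2ccccc2C)cc1OC` — 56100 nM

In a toxicity assay on L02 cells (Homo sapiens) for cytotoxicity, read by MTT assay, with a stated time of 24 h (a lower number here means that less compound is tolerated, a higher number that more compound is tolerated), compound 1 gives the lowest of the three numbers. Compound 2 sits within the scatter of it (a 1.5-fold higher number from compound 1 to compound 2 (0.18 log units; within the scatter)), whereas compound 3 lies far higher (a 17-fold higher number from compound 1 to compound 3 (1.23 log units; beyond the scatter)). Compound 4 `CCCCS(=O)(=O)Oc1ccc(/C=C/C(=O)Nc2ccccc2I)cc1OC` differs from compound 1 by iodo in place of hydrogen on an aromatic carbon. Bromo and iodo are both halogens entering the same aromatic carbon, so the bromo step a 1.5-fold higher number from compound 1 to compound 2 (0.18 log units; within the scatter) is the closest guide, and it stayed within the scatter; the methyl step a 17-fold higher number from compound 1 to compound 3 (1.23 log units; beyond the scatter) involves no halogen and is a weaker guide. A small rise, likely within the scatter, is therefore expected, a 1.4-fold higher number from compound 1 to compound 4 (0.13 log units; within the scatter). Compound 4 is estimated at 4500 nM, with a range from 2000 nM to 12000 nM.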

Compound 4, half-maximal cytotoxic concentration: 24500 nM
For compound 4 the middle estimate is 5.4-fold (0.74 log units) below the measured one; the whole stated range lies below it.
By their numbers in this assay, from the lowest: compounds 1 and 2 (each within the scatter of the next); then compound 4; then compound 3.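

In this assay the two halogens do not behave alike on this aromatic carbon, since iodo gives a 7.4-fold higher number from compound 1 to compound 4 (0.87 log units; beyond the scatter) and swapping bromo for iodo gives a 4.9-fold higher number from compound 2 to compound 4 (0.69 log units; beyond the scatter) while the bromo step from hydrogen stayed within the scatter. Iodo also does not reach methyl, with a 2.3-fold lower number from compound 3 to compound 4 (0.36 log units; beyond the scatter) and so its number lies between those of bromo and methyl. Nothing available explains why iodo and bromo part here.

From the compounds shown here alone, whether fluoro or chloro at this carbon would track bromo or iodo remains open. How an amine or a carboxylic acid would read here is also unknown.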